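The compounds below may be only part of what the source reports. "The series", "measured", "known", "first", "only" and "open" are said of these compounds alone.

In a functional assay on MOLT-3 cells (Homo sapiens) for cytotoxicity, read by crystal violet staining, with a stated time of 3 days (a higher number here means a weaker inhibitor, a lower number a stronger inhibitor), compound 1 `COc1cc2c(cc1OC)C(/C(C)=N/NC(N)=S)N(S(=O)(=O)c1ccc(C)cc1)CC2` is reported as > 50 ug/mL, which is a limit and not a number. Compound 2 `C/C(=N\NC(N)=S)C1c2ccccc2CCN1S(=O)(=O)c1ccc(C)cc1` gives 19 ug/mL and compound 3 `C/C(=N\NC(N)=S)C1c2ccccc2CCN1S(=O)(=O)c1ccc([N+](=O)[O-])cc1` gives 18.3 ug/mL. Going by the values given here, these two numbers lie within the scatter of each other, so compound 3 stands level with compound 2, the only other compound with a measured number.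

Compound 4 `C/C(=N\NC(N)=S)C1c2ccccc2CCN1S(=O)(=O)c1cccc([N+](=O)[O-])c1` differs from compound 3 in one place: 3-nitrophenyl in place of 4-nitrophenyl on a sulfonyl sulfur. Here 3-nitrophenyl takes the place of 4-nitrophenyl on a sulfonyl sulfur, so the two compounds have the same atoms, joined differently. Among the compounds with values here, no measured pair tests this exact change. The nearest evidence is a different swap on the same group, nitro in place of methyl, which gave a 1.0-fold lower number from compound 2 to compound 3 (0.02 log units; within the scatter) and stayed within the scatter. On that single step, the change expected in this assay is a 1.0-fold higher number from compound 3 to compound 4 (0.02 log units; within the scatter), an estimate with no direction beyond the scatter. For compound 4 the estimated value is 19 ug/mL, with an expected range from 10 ug/mL to 38 ug/mL.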

Compound 4, half-maximal inhibitory concentration: 18.1 ug/mL
For compound 4 the middle estimate is 1.0-fold (0.02 log units) above the measured one; the measured number falls inside the stated range.
By their numbers in this assay, from the lowest: compounds 4, 3 and 2 (each within the scatter of the next). At a limit, above all of these: compound 1.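

In this assay, going by these compounds alone, 3-nitrophenyl in place of 4-nitrophenyl on a sulfonyl sulfur gives a 1.0-fold lower number from compound 3 to compound 4 (0.00 log units; within the scatter), so this is the first test of where the nitro group sits on that ring, and the two placements cannot be told apart. The other new step, a 1.0-fold lower number from compound 2 to compound 4 (0.02 log units; within the scatter), shows that 3-nitrophenyl also stands level with 4-methylphenyl at this place. The three groups on this sulfur therefore give numbers that do not separate, and nothing shown here explains why.

From the compounds shown here alone, it remains open whether an amine or a carboxylic acid on this aromatic ring would separate the numbers. A longer chain in place of the ring on the sulfonyl sulfur is equally untested by the compounds shown.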